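The source may hold more compounds than are shown below. What is called first, only, known or untested is meant among the compounds shown, and "the series" means these compounds.

The measured compounds, in brief:

Compound 1, `Cc1ccc(Cn2cc(COc3ccc4c(=O)ccoc4c3)nn2)cc1`, gives 10400 nM in a functional assay on SW480 cells (Homo sapiens) for cytotoxicity, read by MTT assay, with a stated time of 48 h; on this read-out lower numbers stand for stronger inhibition and higher numbers for weaker inhibition.
Compound 3, `O=c1ccoc2cc(OCc3cn(Cc4cccc(Cl)c4)nn3)ccc12`, gives 12900 nM in this assay.
Compound 2, `O=c1ccoc2cc(OCc3cn(Cc4ccc(Cl)cc4Cl)nn3)ccc12`, reaches only a limit in this assay, > 100000 nM.

Compound 1 holds the lowest of the two numbers actually read; its nearest neighbour is compound 3, with a 1.2-fold higher number from compound 1 to compound 3 (0.09 log units; within the scatter). Compound 2 stands apart, since its value is a limit (the limit of > 100000 nM in this assay, at which 1 of the 3 values shown sits), and the step of an at least 9.6-fold higher number from compound 1 to compound 2 (0.98 log units; beyond the scatter) goes well beyond the scatter, as does an at least 7.7-fold lower number from compound 2 to compound 3 (0.88 log units; beyond the scatter).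

Compound 4, `O=c1ccoc2cc(OCc3cn(Cc4ccc([N+](=O)[O-])cc4)nn3)ccc12`, remains to be measured. It differs from compound 1 by nitro in place of methyl on an aromatic carbon. Going by the values given here, none of the measured steps exchanges methyl for nitro, so no step bears directly on this change. What the set does show is that one exchange of the benzylic ring, 4-methylphenyl to 3-chlorophenyl, stays within the scatter, while 4-methylphenyl to 2,4-dichlorophenyl moves the number beyond it. Compound 4 carries a single ring substituent, as compound 1 and compound 3 do, so a step within the scatter, or at most a modest rise, is expected in this assay.

Compound 4 is therefore estimated at 15000 nM, within a range of 5000 nM to 60000 nM, which corresponds to an expected 1.4-fold higher number from compound 1 to compound 4 (0.16 log units; within the scatter).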

Compound 4, half-maximal inhibitory concentration: 19300 nM
Compound 4: middle estimate off by 1.3-fold (0.11 log units), on the low side; the measured number falls inside the stated range.
By their numbers in this assay, from the lowest: compounds 1, 3 and 4 (each within the scatter of the next). At a limit, above all of these: compound 2.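

In this assay, nitro in place of methyl on the aromatic carbon para to a large group gives a 1.9-fold higher number from compound 1 to compound 4 (0.27 log units; within the scatter), so at this position the read-out does not separate the two groups, although the incoming group is the larger one and brings hydrogen-bond acceptors that methyl lacks. The 4-nitrophenyl ring also cannot be told apart from the 3-chlorophenyl ring, with a 1.5-fold higher number from compound 3 to compound 4 (0.17 log units; within the scatter), which makes compounds 1, 3 and 4 a set of singly substituted rings that all sit within the scatter of one another. Going by these compounds alone, compound 2 is the one compound that goes against this, with an at least 5.1-fold lower number from compound 2 to compound 4 (0.71 log units; beyond the scatter), and its value is a limit, not a number: the limit of > 100000 nM in this assay, at which 1 of the 4 values shown sits.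

The compounds shown leave open whether the departure of compound 2 would also appear with 2-chlorophenyl or 4-chlorophenyl alone, since the 2,4-dichlorophenyl ring is the only ring here with two substituents. They also leave open how an amine or a carboxylic acid would read on the same aromatic carbon, and how a longer chain would read in place of the saturated chain carbon.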